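This account rests on a few compounds, and the source may have more. Where it says the series, first, only, none or still open, it means among the compounds named here.

Compound 1, `Cc1cc(O)c(C2=NN(c3ccc(S(N)(=O)=O)cc3)C(c3ccccc3Cl)C2)cc1Cl`, in a functional assay on A549 cells (Homo sapiens) for antiproliferative activity, with a stated time of 48 h (on this read-out lower numbers stand for higher toxicity in this test and higher numbers for lower toxicity in this test), gives > 100000 nM, which is a limit of the test rather than a number.
Compound 2, `COc1ccc(C2CC(c3cc(Cl)c(C)cc3O)=NN2c2ccc(S(N)(=O)=O)cc2)cc1OC`, in this assay gives > 100000 nM, again a limit rather than a number.

Among the compounds with values here, compound 2 therefore stands at a limit, with no readable number behind it, and the only measured step, a step that the two limits leave unreadable from compound 1 to compound 2, cannot be read, as the limit of > 100000 nM in this assay, at which 2 of the 2 values shown sit, shows where the two values sit. Compound 3, `COc1ccc(C2CC(c3cc(Cl)c(C)cc3O)=NN2c2ccc(S(N)(=O)=O)cc2)c(OC)c1OC`, differs from compound 2 by methoxy in place of hydrogen on an aromatic carbon. Within the data shown here, no measured step with a readable size bears on this change, so nothing can be carried over, and in this assay the expectation is that compound 3 shows no step beyond the scatter and most likely stays at the limit. Compound 3 is estimated at 200000 nM, with a range from 50000 nM to 1000000 nM, which means an expected step that the limit leaves unreadable from compound 2 to compound 3.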

Compound 3, concentration lethal to 50% of the cells: 80300 nM
Compound 3: middle estimate off by 2.5-fold (0.40 log units), on the high side; the measured number falls inside the stated range.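

In this assay, within the data shown here, compound 3 is the first compound to give a readable number instead of a limit, so this position, ortho to a large group and ortho to a methoxy group, now has a measured value to work from. Methoxy in place of hydrogen here gives an at least 1.2-fold lower number from compound 2 to compound 3 (0.09 log units; that floor lies within the scatter), and the 2,3,4-trimethoxyphenyl group in place of 2-chlorophenyl gives an at least 1.2-fold lower number from compound 1 to compound 3 (0.09 log units; that floor lies within the scatter). Both are only minimum sizes, so neither change is shown to go beyond the scatter, and the true size of each step stays hidden: the limit of > 100000 nM in this assay, at which 2 of the 3 values shown sit.

As far as these compounds go, how far compound 1 and compound 2 really lie from compound 3 remains open. Also open, from the compounds shown here alone, is what a hydroxyl group, a fluorine atom or an amine would do on this same aromatic carbon.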